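Removing One Methoxy Group from Compound 1

This account rests on a few compounds, and the source may have more. Where it says the series, first, only, none or still open, it means among the compounds named here.

Measured so far in a functional assay on L1210 cells (Mus musculus) for antiproliferative activity, read by cell counting, with a stated time of 96 h; on this read-out lower numbers stand for stronger inhibition and higher numbers for weaker inhibition: compound 1 `COc1ccc(Oc2ccccc2NC(C)=C2C(=O)CC(c3ccccc3)CC2=O)cc1OC` gives 65 nM; compound 2 `CC(Nc1ccccc1Oc1ccccc1)=C1C(=O)CC(c2ccccc2)CC1=O` gives 86 nM; compound 3 `CC(Nc1ccccc1Oc1ccc(C(C)O)cc1)=C1C(=O)CC(c2ccccc2)CC1=O` gives 58 nM.

All three compounds share the same core and differ only in the aromatic ring carried on the oxygen. On these numbers compound 1 stands second highest of the three, with compound 3 nearest and compound 2 furthest, and every pairwise step lies within the scatter: a 1.3-fold higher number from compound 1 to compound 2 (0.12 log units; within the scatter), a 1.1-fold lower number from compound 1 to compound 3 (0.05 log units; within the scatter) and a 1.5-fold lower number from compound 2 to compound 3 (0.17 log units; within the scatter). None of the three can therefore be called stronger or weaker than another.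

Compound 4 `COc1cccc(Oc2ccccc2NC(C)=C2C(=O)CC(c3ccccc3)CC2=O)c1` has not been measured. The change from compound 1 is hydrogen in place of methoxy on an aromatic carbon. Among the compounds with values here, two measured steps bear on it. The step from compound 1 to compound 2 exchanges 3,4-dimethoxyphenyl for plain phenyl, a larger removal than the single methoxy lost here, and stayed within the scatter. The step from compound 1 to compound 3 also replaced the 3,4-dimethoxyphenyl group and stayed within the scatter. A smaller change than either is therefore expected to give no step beyond the scatter in this assay. Compound 4 is estimated at 70 nM, with a range from 35 nM to 140 nM, which is expected to mean a 1.1-fold higher number from compound 1 to compound 4 (0.03 log units; within the scatter).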

Compound 4, half-maximal inhibitory concentration: 58 nM
Estimate against measurement, compound 4: 1.2-fold (0.08 log units) above; measured number inside the range.
By their numbers in this assay, from the lowest: compounds 3, 4, 1 and 2 (each within the scatter of the next).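

Taking one methoxy group off the 3,4-dimethoxyphenyl ring, at the carbon ortho to a methoxy group and para to a large group, gives a 1.1-fold lower number from compound 1 to compound 4 (0.05 log units; within the scatter) in this assay and leaves 3-methoxyphenyl in its place. Within the data shown here, the earlier compounds changed that ring only as a whole, so this is the first view of this single position, and the loss of this methoxy group alone stays within the scatter. Adding the remaining methoxy group to the plain phenyl ring gives a 1.5-fold lower number from compound 2 to compound 4 (0.17 log units; within the scatter) and exchanging 4-(1-hydroxyethyl)phenyl for 3-methoxyphenyl gives no change at the digits printed from compound 3 to compound 4 (within the scatter), so all four compounds now sit within the scatter of their neighbours in this order, and no single change on this ring separates them.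

No measurement here explains why these changes leave the number so little moved. The compounds shown leave open whether this carbon would stay as undemanding with a different group, such as an amine, a carboxylic acid or a longer alkoxy chain, and how a ring carrying only the 4-methoxy group would compare.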